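A few compounds are considered here, and "the series" means these few. Any claim that something is new, unique, unknown or untested is made for them only; others in the source may bear on it.

Compound 1 `O=C(O)CCC[C@H](O)[C@@H](/C=C\CCCCCCCCc1ccccc1)Sc1ccc(C(=O)O)cc1` gives 316 nM in an assay on membranes from lung for binding affinity to cysteinyl leukotriene receptor 1 (Cavia porcellus); a lower number here means a stronger inhibitor, a higher number a weaker inhibitor. Compound 2 `O=C(O)CCC[C@H](O)[C@@H](/C=C\CCCCCCCCOc1ccccc1)Sc1ccc(C(=O)O)cc1` gives 631 nM in this assay.

Compound 2 and compound 1 lie within the scatter of each other, as the step of a 2.0-fold higher number from compound 1 to compound 2 (0.30 log units; within the scatter) shows. Compound 3 `O=C(O)CCC[C@H](O)[C@@H](/C=C\CCCCCCCCCCCCCc1ccccc1)Sc1ccc(C(=O)O)cc1` is not yet measured; it differs from compound 2 by 5-phenylpentyl in place of phenoxy on a saturated chain carbon, eight bonds along the chain from a double-bonded chain carbon. Among the compounds with values here, the only measured step touches the same chain carbon, swapping phenyl for phenoxy, and it stayed within the scatter; it says little about a longer 5-phenylpentyl group. Compound 3 is therefore expected to land near compound 2, with a 1.6-fold lower number from compound 2 to compound 3 (0.20 log units; within the scatter) a step of uncertain direction. The estimate for compound 3 is 400 nM, within 130 nM to 1300 nM.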

Compound 3, inhibition constant: 5010 nM
Compound 3: middle estimate off by 13-fold (1.10 log units), on the low side; the measured number lies above the stated range.
By their numbers in this assay, from the lowest: compounds 1 and 2 (each within the scatter of the next); then compound 3.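

In this assay the changes a 7.9-fold higher number from compound 2 to compound 3 (0.90 log units; beyond the scatter) and a 16-fold higher number from compound 1 to compound 3 (1.20 log units; beyond the scatter) show that this position does respond to the group placed on it. The swap of phenyl for phenoxy stayed within the scatter, but 5-phenylpentyl on the same saturated chain carbon gives a weaker inhibitor than either group. No measurement here explains this loss. On these data alone, whether the number climbs gradually or suddenly between phenyl and 5-phenylpentyl remains open, and 2-phenylethyl or 3-phenylpropyl would bear on that. As far as these compounds go, how an amine or a carboxylic acid would compare at this place also stays open.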